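This account rests on a few compounds, and the source may have more. Where it says the series, first, only, none or still open, it means among the compounds named here.

Compound 2 `Nc1cc(-c2ccncc2NC(=O)c2nc(-c3c(F)cccc3F)ccc2N)nc(C(F)(F)F)n1` was measured in an ADME assay on liver with Liver microsome (Rattus norvegicus) as the target, read by LC-MS, using microsomes, with a stated time of 30 min, tested at 1 uM (a lower number here means that the liver removes a smaller share, a higher number that the liver removes a larger share of the compound in one pass), where compound 2 gives 0.91. Among the two compounds measured so far it carries the higher number, but the only neighbour, compound 1 `Cc1nc(N)cc(-c2ccncc2NC(=O)c2nc(-c3c(F)cccc3F)ccc2N)n1`, gives 0.82 in this assay, and the step a number 0.090 higher from compound 1 to compound 2 (within the scatter) lies within the scatter, so the two cannot be ranked.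

Compound 3 `Nc1cc(-c2ccncc2NC(=O)c2nc(-c3nccs3)ccc2N)nc(C(F)(F)F)n1` has not yet been measured. It differs from compound 2 at a single site: 1,3-thiazol-2-yl in place of 2,6-difluorophenyl on an aromatic carbon. The 2,6-difluorophenyl group leaves and 1,3-thiazol-2-yl enters, on an aromatic carbon of the six-membered aromatic ring with one nitrogen, para to an amino group.

Within the data shown here, no measured step bears directly on this change. Among the measured compounds shown here, the single step on record, from methyl to trifluoromethyl at a different position, moved the number by an amount within the scatter. With nothing to push the expectation either way, compound 3 is expected to stay close to compound 2, with an expected step of a number 0.040 lower from compound 2 to compound 3 (within the scatter). The estimate for compound 3 in this assay is therefore 0.87, with a range from 0.7 to 0.97.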

Compound 3, hepatic extraction ratio: 0.89
Estimate against measurement, compound 3: 0.020 below; measured number inside the range.
By their numbers in this assay, from the lowest: compounds 1, 3 and 2 (each within the scatter of the next).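

At the aromatic carbon para to an amino group, next to the ring nitrogen, the change of 2,6-difluorophenyl to 1,3-thiazol-2-yl reads in this assay as a number 0.020 lower from compound 2 to compound 3 (within the scatter), so the two compounds cannot be told apart. This site therefore accepts a five-membered aromatic ring with 2 hetero atoms in place of a six-membered aromatic ring of carbon only, with fewer heavy atoms and with hydrogen-bond acceptors where the leaving group has none, and still no step beyond the scatter appears in the hepatic extraction ratio. Nothing measured here bears on what lies behind this result.

What the compounds shown leave open is whether any group on this carbon can move the number beyond the scatter, for instance a simple amine, a carboxylic acid or a longer alkyl chain in place of the aromatic ring. Also open, as far as these compounds go, is whether 1,3-thiazol-2-yl would read the same with methyl in place of trifluoromethyl, as in the core of compound 1, since this change is seen only alongside trifluoromethyl.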